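This account rests on a few compounds, and the source may have more. Where it says the series, first, only, none or still open, it means among the compounds named here.

Working notes on the series. Going by the values given here, in a functional assay on Bel-7402 cells (Homo sapiens) for antiproliferative activity, read by MTT assay, with a stated time of 48 h (a lower number here means a stronger inhibitor of growth, a higher number a weaker inhibitor of growth), compound 1 (`COc1ccc(/C=C2\Cc3c(cc(OC)c(OC)c3OC)C2=O)cc1[N+](=O)[O-]`) gives 950 nM and is the only compound so far with a true number. Compound 2 (`COc1ccc(/C=C2\Cc3cc(OC)c(OC)c(OC)c3C2=O)cc1O`) stands at > 10000 nM in this assay and this value is a limit of the assay, not a number.

Compound 3 (`COc1ccc(/C=C2\Cc3cc(OC)c(OC)c(OC)c3C2=O)cc1`) differs from compound 2 by a single change (hydrogen in place of hydroxy on an aromatic carbon), hydrogen in place of hydroxy on an aromatic carbon, ortho to a methoxy group. Among the compounds with values here, no measured pair isolates this change, so its size cannot be read from the data. The expectation therefore starts from compound 2 at > 10000 nM as a limit of the assay.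

A small move towards stronger inhibition of growth is expected, with a real chance that compound 3 also reports only a limit. The estimate is an at least 1.4-fold lower number from compound 2 to compound 3 (0.15 log units; that floor lies within the scatter) and is meant as a modest expected step. Compound 3 is expected at 7000 nM in this assay with an estimated range of 1500 nM to 30000 nM on the same read-out.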

Compound 3, concentration for 50% growth inhibition: > 10000 nM
Compound 3 was reported as a limit; the forecaster's own chance of this, stated with the estimate: 50%; at least 1.4-fold (0.15 log units) between middle value and limit.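

No step from compound 2 to compound 3 can be read in this assay, because both compounds report only a limit of the assay and not a number: the limit of > 10000 nM in this assay, at which 2 of the 3 values shown sit.

The compounds shown leave open whether hydrogen in place of hydroxy on an aromatic carbon, ortho to a methoxy group, changes the inhibition of growth at all, and in which direction.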